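The compounds below may be only part of what the source reports. "The series", "measured", "known", "first", "only" and "open" are said of these compounds alone.

Compound 1 `Cc1noc(NS(=O)(=O)c2cccc3c(CN(C)C)cccc23)c1C` carries a (dimethylamino)methyl group on its fused two-ring system. For the measured compounds named here, in an assay on VSM-A10 cells for antagonist activity at Endothelin-1 receptor (Rattus norvegicus) (on this read-out higher numbers stand for weaker inhibition and lower numbers for stronger inhibition), compound 1 gives 2800 nM, the lowest of the two numbers measured so far. Going by the values given here, the only other measured compound, compound 2 `Cc1noc(NS(=O)(=O)c2cccc3c(N(C)C)cccc23)c1[N+](=O)[O-]`, differs from compound 1 in two places at once. In this assay compound 2 gives 17300 nM. Among the compounds with values here, the gap between the two lies beyond the scatter; no single step between them can be drawn from that pair.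

Compound 3 `Cc1noc(NS(=O)(=O)c2cccc3c(N4CCCC4=O)cccc23)c1C` has not yet been measured. It differs from compound 1 by 2-oxopyrrolidin-1-yl in place of (dimethylamino)methyl on an aromatic carbon. Within the data shown here, no measured pair shows what this kind of change does here, so the direction rests on expectation alone. A modest step toward a higher number is expected, of a size near the edge of the scatter, as a 1.6-fold higher number from compound 1 to compound 3 (0.21 log units; within the scatter). For compound 3 the estimate in this assay is 4500 nM, within a range from 1200 nM to 17000 nM.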

Compound 3, half-maximal inhibitory concentration: 130 nM
Compound 3: the middle estimate sits 35-fold (1.54 log units) above what was measured; measured number below the stated range.
By their numbers in this assay, from the lowest: compound 3; then compound 1; then compound 2.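

Replacing (dimethylamino)methyl with 2-oxopyrrolidin-1-yl on this aromatic carbon gives a 22-fold lower number from compound 1 to compound 3 (1.33 log units; beyond the scatter) in this assay, a large step with only one place changed. For the compounds shown here, the earlier pair differed in two places at once, so only this step shows that the group at this position alone can move the number a long way toward stronger inhibition. The entering group adds a five-membered non-aromatic ring and a double bond outside aromatic rings, but no measurement here explains the step.

The compounds shown leave open whether the ring, its carbonyl or both account for the step, which a plain pyrrolidine ring or an open-chain acetamide at this position could help separate. A six-membered piperidin-2-one ring would likewise test how much the ring size matters.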